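The compounds below may be only part of what the source reports. "The series", "measured", "known", "first", "only" and "open" are said of these compounds alone.

Of the compounds shown here, three sharing one core have been measured in a physicochemical assay for lipophilicity; on this read-out higher numbers stand for higher lipophilicity and lower numbers for lower lipophilicity. Compound 1 `COc1ccc(C2=NO[C@]3(C2)C(=O)O[C@@H]2[C@H]3CC[C@H](C)[C@]3(O)C=CC(=O)[C@@]23C)cc1OC` gives 1.06, compound 2 `C[C@H]1CC[C@@H]2[C@@H](OC(=O)[C@]23CC(c2ccc(F)cc2)=NO3)[C@]2(C)C(=O)C=C[C@@]12O` gives 1.58, and compound 3 `C[C@H]1CC[C@@H]2[C@@H](OC(=O)[C@]23CC(c2ccc(F)cc2)N(c2ccccc2)O3)[C@]2(C)C(=O)C=C[C@@]12O` gives 3.35, the highest of the three numbers and beyond the scatter from both others.

Compound 4 `Cc1ccccc1C1C[C@@]2(ON1c1ccccc1)C(=O)O[C@@H]1[C@H]2CC[C@H](C)[C@]2(O)C=CC(=O)[C@@]12C` has not yet been measured. It differs from compound 3 in one place, with 2-methylphenyl in place of 4-fluorophenyl on a saturated ring carbon.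

Among the measured compounds shown here, only one measured step exchanges one substituted phenyl group for another, and that is a number 0.52 log units higher from compound 1 to compound 2 (beyond the scatter). This modest step is only a loose guide, as it involves a different outgoing group and sits on a carbon with a double bond to nitrogen. For the measured compounds named here, no measured step tests the present exchange directly.

A small rise in this assay is therefore expected, smaller than the step to compound 2 and possibly within the scatter. The expected change is a number 0.25 log units higher from compound 3 to compound 4 (within the scatter). The estimate for compound 4 is 3.6, with an expected range from 3.15 to 4.05.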

Compound 4, partition coefficient: 3.64
Beside the measured number, compound 4's estimate is 0.04 log units below it, within the range that was stated.
By their numbers in this assay, from the lowest: compound 1; then compound 2; then compounds 3 and 4 (each within the scatter of the next).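

In this assay, among the compounds shown here, this is the first exchange of one substituted phenyl group for another on a saturated ring carbon of the five-membered ring with one nitrogen and one oxygen, and it gives a number 0.29 log units higher from compound 3 to compound 4 (within the scatter). So at this position, 2-methylphenyl and 4-fluorophenyl cannot be told apart on this read-out. For the compounds shown here, the only earlier exchange of this kind, a number 0.52 log units higher from compound 1 to compound 2 (beyond the scatter), lies beyond the scatter, but it has a different outgoing group and sits on a carbon with a double bond to nitrogen, so the two steps do not describe the same position.

From the compounds shown here alone, whether an amine or a carboxylic acid on this same ring carbon would also stay within the scatter of compound 3 remains open. Nothing shown gives a reason for the result of this exchange.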